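Removing one methoxy group from a weak pyrimidine inhibitor

The source may report more compounds than this note shows. Statements on the series, on what has been measured and on what is new or still open speak of the compounds shown alone.

Compound 1 `COc1ccc(OC)c(Nc2cc(Nc3ccc(F)cc3)ncn2)c1` and compound 2 `COc1cccc(Nc2cc(Nc3cc(OC)ccc3OC)ncn2)c1` share a core with compound 3 `COc1ccc(OC)c(Nc2cc(NC(=O)CCCC(=O)O)ncn2)c1`. In an assay for inhibition of Receptor tyrosine-protein kinase erbB-3 variant L858R (Homo sapiens), read by mobility shift assay, with a stated time of 10 min (a lower number here means a stronger inhibitor, a higher number a weaker inhibitor), compound 1 gives 230 nM and compound 2 gives 18 nM, a change of a 13-fold lower number from compound 1 to compound 2 (1.11 log units; beyond the scatter). Compound 3 reaches only the limit of > 10000 nM in this assay, at which 1 of the 3 values shown sits, and gives > 10000 nM. The steps of an at least 43-fold higher number from compound 1 to compound 3 (1.63 log units; beyond the scatter) and an at least 550-fold higher number from compound 2 to compound 3 (2.74 log units; beyond the scatter) show that the acid-bearing chain in place of an aryl group costs much activity. Compound 4 `COc1cccc(Nc2cc(NC(=O)CCCC(=O)O)ncn2)c1` keeps that chain and differs from compound 3 by hydrogen in place of methoxy on an aromatic carbon. Among the compounds with values here, no measured step tests this change, so compound 4 is expected to stay near the limit, with a step of about a number no higher from compound 3 to compound 4 (the limit leaves the size open). Compound 4 is therefore estimated at 10000 nM, within 3000 nM to 30000 nM.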

Compound 4, half-maximal inhibitory concentration: 31 nM
Compound 4: middle estimate off by 320-fold (2.51 log units), on the high side; measured number outside the range, below it.
By their numbers in this assay, from the lowest: compounds 2 and 4 (each within the scatter of the next); then compound 1. At a limit, above all of these: compound 3.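

In this assay, hydrogen in place of methoxy gives an at least 320-fold lower number from compound 3 to compound 4 (2.50 log units; beyond the scatter), so this one position, ortho to a large group, decides whether the acid-bearing chain is tolerated. The earlier compounds shown here suggested that the chain itself cost the activity, yet compound 4 sits within the scatter of compound 2. The true step may be larger still, as compound 3 stands at a limit: the limit of > 10000 nM in this assay, at which 1 of the 4 values shown sits.

From the compounds shown here alone, whether a hydroxyl, an ethoxy group or a fluorine at this position would behave like hydrogen or like methoxy remains open. So does whether an amine at the chain end would give the same result as the carboxylic acid.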